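Methoxy to methoxymethyl on the chain amine

A few compounds are considered here, and "the series" means these few. Any claim that something is new, unique, unknown or untested is made for them only; others in the source may bear on it.

The shared core of compound 1 `CC(C)(C)OC(=O)Nc1ncc(C(Oc2ccc3cc(Br)ccc3c2)c2ccc(Cl)cc2)s1` carries a carbamate on its aromatic nitrogen. Compound 1 gives in an ADME assay on HepG2 2.2.15 cells (Homo sapiens) for cytotoxicity (a lower number here means that less compound is tolerated, a higher number that more compound is tolerated), a value of > 50000 nM, which is a limit of the assay and not a number. Compound 2 `O=C(Nc1ncc(C(Oc2ccc3cc(Br)ccc3c2)c2ccc(Cl)cc2)s1)c1cccs1` gives "not toxic" (no number reported) in this assay, and compound 3 `COCCNc1ncc(C(Oc2ccc3cc(Br)ccc3c2)c2ccc(Cl)cc2)s1` likewise gives "not toxic" (no number reported) in this assay. Compound 3 thus stands with no number of its own; of the other two entries one is a limit and one has no number, as the evidence shows (the limit of > 50000 nM in this assay, at which 1 of the 3 values shown sits). Compound 4 `COCCCNc1ncc(C(Oc2ccc3cc(Br)ccc3c2)c2ccc(Cl)cc2)s1` differs from compound 3 by methoxymethyl in place of methoxy on a saturated chain carbon, two bonds along the chain from a nitrogen on an aromatic ring. Going by the values given here, no step between measured compounds exists here, and in this assay no shift beyond the scatter is expected from this change. Compound 4 is expected to give 50000 nM, with a range from 20000 nM to 100000 nM.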

Compound 4, half-maximal cytotoxic concentration: "not toxic" (no number reported)
Nothing numeric was reported for compound 4; the estimate stays without a comparison.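

Compound 3 and compound 4 are both reported only as "not toxic" in this assay, so no step can be read between them. The compounds shown leave open how far either lies from the limit that compound 1 reaches: the limit of > 50000 nM in this assay, at which 1 of the 4 values shown sits.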